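Carbamate to benzamide swap on the protected amine

This account rests on a few compounds, and the source may have more. Where it says the series, first, only, none or still open, it means among the compounds named here.

Compound 1 `O=C(CCCSC[C@H](NC(=O)OCc1ccccc1)C(=O)Nc1ccccc1)NO` is known in an assay on isolated protein for inhibition of histone deacetylase 4 (Homo sapiens), read by fluorescence, with a stated time of 1 h (a higher number here means a weaker inhibitor, a lower number a stronger inhibitor), only as a limit: compound 1 gives > 200 nM. Compound 2 `O=C(CCCSC[C@H](NC(=O)OCc1ccccc1)C(=O)Nc1cccc2ccccc12)NO` likewise reaches only a limit, giving > 200 nM in this assay. The change naphthalen-1-yl in place of phenyl on an amide-type nitrogen is therefore a step that the two limits leave unreadable from compound 1 to compound 2; both values sit at the limit of > 200 nM in this assay, at which 2 of the 2 values shown sit. Compound 3 `O=C(CCCSC[C@H](NC(=O)c1ccccc1)C(=O)Nc1ccccc1)NO` carries phenyl in place of benzyloxy on a carbonyl carbon. Going by the values given here, no measured step touches this position, and neither value shown is a number; size and direction stay unreadable. Compound 3 is expected at 400 nM, between 150 nM and 3000 nM. The expected step is a step that the limit leaves unreadable from compound 1 to compound 3.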

Compound 3, half-maximal inhibitory concentration: > 200 nM
Compound 3 was reported as a limit; the forecaster's own chance of this, stated with the estimate: 75%; the middle value is on the limit's open side.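

Compound 3, like compound 1, gives only a limit in this assay, and no new step from compound 1 to compound 3 can be read: the limit of > 200 nM in this assay, at which 3 of the 3 values shown sit.

The compounds shown leave open how strongly each inhibits, and whether phenyl in place of benzyloxy on the carbonyl carbon changes that at all.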